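The source may hold more compounds than are shown below. What is called first, only, known or untested is meant among the compounds shown, and "the series" means these compounds.

Of the compounds shown here, three share one core and have been tested so far. Compound 1 `CCOC(=O)C1=Cc2ccccc2OC1(OCc1cn(-c2ccc(F)cc2)nn1)C(F)(F)F` gives 8400 nM in a functional assay on HeLa cells (Homo sapiens) for inhibition, read by MTT assay, with a stated time of 24 h; a higher number here means a weaker inhibitor, a lower number a stronger inhibitor. Compound 2 `CCOC(=O)C1=Cc2ccccc2OC1(OCc1cn(CC(=O)Nc2ccc(OC)cc2)nn1)C(F)(F)F` gives 31900 nM in this assay, a change of a 3.8-fold higher number from compound 1 to compound 2 (0.58 log units; beyond the scatter). Compound 3 `CCOC(=O)C1=Cc2ccccc2OC1(OCc1cn(-c2ccccc2)nn1)C(F)(F)F` reaches only the upper limit of this assay, > 150000 nM, which is the limit of > 150000 nM in this assay, at which 1 of the 3 values shown sits. Compound 4 `CCOC(=O)C1=Cc2ccccc2OC1(OCc1cn(-c2ccc(F)c([N+](=O)[O-])c2)nn1)C(F)(F)F` is not yet measured; it differs from compound 3 by 4-fluoro-3-nitrophenyl in place of phenyl on an aromatic nitrogen. Among the compounds with values here, two measured steps bear on this change: an at least 17-fold higher number from compound 1 to compound 3 (1.25 log units; beyond the scatter), and an at least 4.7-fold higher number from compound 2 to compound 3 (0.67 log units; beyond the scatter). Since the 4-fluoro-3-nitrophenyl group brings back the fluoro whose loss gave that large step, a strongly lower number is expected, a step of an at least 15-fold lower number from compound 3 to compound 4 (1.17 log units; beyond the scatter). Compound 4 is therefore estimated at 10000 nM, within a range from 3000 nM to 50000 nM.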

Compound 4, half-maximal inhibitory concentration: 15600 nM
Beside the measured number, compound 4's estimate is 1.6-fold (0.19 log units) below it, within the range that was stated.
By their numbers in this assay, from the lowest: compounds 1 and 4 (each within the scatter of the next); then compound 2. At a limit, above all of these: compound 3.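

On the aromatic nitrogen, the 4-fluorophenyl group tolerates an added nitro group, with a 1.9-fold higher number from compound 1 to compound 4 (0.27 log units; within the scatter). Replacing phenyl with 4-fluoro-3-nitrophenyl gives an at least 9.6-fold lower number from compound 3 to compound 4 (0.98 log units; beyond the scatter), a step read against a limit of the assay: the limit of > 150000 nM in this assay, at which 1 of the 4 values shown sits. Replacing the ((4-methoxyphenyl)carbamoyl)methyl group with 4-fluoro-3-nitrophenyl gives a 2.0-fold lower number from compound 2 to compound 4 (0.31 log units; beyond the scatter), a modest step.

Going by these compounds, whether a nitro group without the fluoro could also lower the number on phenyl remains open. So does how an amine or a carboxylic acid in place of the nitro group would behave in this assay.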